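A few compounds are considered here, and "the series" means these few. Any claim that something is new, unique, unknown or untested is made for them only; others in the source may bear on it.

Measured so far in an ADME assay on Huh-7 cells (Homo sapiens) for cytotoxicity; on this read-out lower numbers stand for higher toxicity in this test and higher numbers for lower toxicity in this test:

Compound 1, `O=c1cc(CNCc2ccccc2I)oc2ccc(O)c(O)c12`: 87300 nM
Compound 2, `O=c1cc(CNCc2cccc(F)c2)oc2ccc(O)c(O)c12`: a limit only, > 100000 nM

Compound 2 stands at the limit of this assay rather than at a number; its value sits at the limit of > 100000 nM in this assay, at which 1 of the 2 values shown sits. Among the measured compounds shown here, the one measured step, an at least 1.1-fold higher number from compound 1 to compound 2 (0.05 log units; that floor lies within the scatter), is a halogen change on the pendant benzyl ring and lies within the scatter of the read-out. The next compound, compound 3, `O=c1cc(CNCc2cccc(Cl)c2)oc2ccc(O)c(O)c12`, differs from compound 2 by chloro in place of fluoro on an aromatic carbon. For the measured compounds named here, the only step that bears on this change is the halogen swap just described, and it gave no movement beyond the scatter, so for compound 3 no shift beyond the scatter in this assay is expected in either direction. Compound 3 is therefore estimated at 100000 nM, with a range from 50000 nM to 200000 nM, and a fair chance that only a limit is returned. The expected step is a number no higher from compound 2 to compound 3 (the limit leaves the size open).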

Compound 3, half-maximal cytotoxic concentration: > 100000 nM
Compound 3 gave a limit, no number (the forecaster's own chance of this, stated with the estimate: 60%); the middle value sits exactly at the limit.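

In this assay compound 3 returns a limit and no number, so a second halogen at this place also leaves the series without a measured value: the limit of > 100000 nM in this assay, at which 2 of the 3 values shown sit.

The step of chloro in place of fluoro on the aromatic carbon cannot be read, as both of its ends are limits. The change to 3-chlorophenyl in place of 2-iodophenyl gives an at least 1.1-fold higher number from compound 1 to compound 3 (0.05 log units; that floor lies within the scatter), the same floor as the 3-fluorophenyl change, so neither step shows a difference beyond the scatter.

On these data alone, it remains open whether any group at this place yields a number in this assay, for instance an amine or a carboxylic acid in place of the halogen. Also open, as far as these compounds go, is how a longer chain carrying the ring would read out.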